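Swapping a Methoxy for a Trifluoromethyl on the Quinazolinone Core

The compounds below may be only part of what the source reports. "The series", "measured", "known", "first", "only" and "open" are said of these compounds alone.

Measured compounds:
compound 1, `COc1cccc(-c2nc3cc(C)ccc3c(=O)[nH]2)c1`, 8940 nM
compound 2, `COc1cccc(-c2nc3ccc(N4CCCCC4)cc3c(=O)[nH]2)c1OC`, 8190 nM

In a functional assay on HeLa cells (Homo sapiens) for cytotoxicity, read by MTT assay, with a stated time of 2 days (a lower number here means a stronger inhibitor, a higher number a weaker inhibitor), compound 1 gives 8940 nM and compound 2 gives 8190 nM; the gap between them lies within the usual scatter, so the two cannot be told apart. Among the compounds with values here, no pair differing in a single place has been measured, so no step size is known here.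

Compound 3, `Cc1ccc2c(=O)[nH]c(-c3cccc(C(F)(F)F)c3)nc2c1`, differs from compound 1 only by trifluoromethyl in place of methoxy on an aromatic carbon. Within the data shown here, with no comparable step available, the expected change from compound 1 to compound 3 is a 1.3-fold lower number from compound 1 to compound 3 (0.11 log units; within the scatter), small and with no firm direction. Compound 3 is therefore estimated at 7000 nM, within a range of 2500 nM to 20000 nM.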

Compound 3, half-maximal inhibitory concentration: > 50000 nM
Compound 3 gave a limit, no number (the forecaster's own chance of this, stated with the estimate: 15%); middle value at least 7.1-fold (0.85 log units) away from the limit.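

Trifluoromethyl in place of methoxy on this aromatic carbon gives an at least 5.5-fold higher number from compound 1 to compound 3 (0.74 log units; beyond the scatter) in this assay and is the first step measured on the shared core, showing that the group on this carbon matters to the reading. The reading for compound 3 is a limit of the assay, not a number: the limit of > 50000 nM in this assay, at which 1 of the 3 values shown sits.

From the compounds shown here alone, whether an amine, a hydroxyl or a nitrile on this carbon would give a lower number stays open. A single step on a single core also cannot say whether the same swap would act alike elsewhere.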